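The source may report more compounds than this note shows. Statements on the series, on what has been measured and on what is new or still open speak of the compounds shown alone.

Compounds measured in a functional assay (spleen, spleen) for activation, with Mus musculus as the target; on this read-out lower numbers stand for an effect already at smaller amounts and higher numbers for an effect only at larger amounts of compound: compound 1 `Nc1nc(SCc2ccccc2)nc2c1nc(O)n2Cc1ccccc1` gives 0.1 uM; compound 3 `Nc1nc(N)c2nc(O)n(Cc3ccccc3)c2n1` gives 10 uM; compound 2 `COc1nc2c(N)ncnc2n1Cc1ccccc1` gives > 10 uM, which is a limit of the assay and not a number.

Compound 2 therefore stands at the weak end of what has been seen so far, as one of the values sitting at the limit (the limit of > 10 uM in this assay, at which 1 of the 3 values shown sits). The unmeasured compound 4 `CSc1nc2c(N)ncnc2n1Cc1ccccc1` differs from it by methylsulfanyl in place of methoxy on an aromatic carbon. Among the compounds with values here, none of the measured steps touches this position or this pair of groups. Within the data shown here, the single measured step, a 100-fold higher number from compound 1 to compound 3 (2.00 log units; beyond the scatter), concerns a different carbon and a different pair of groups, and so gives no direct guidance for the exchange of methoxy for methylsulfanyl. Among the measured compounds shown here, with only a limit for compound 2 and no related step, no movement beyond the scatter can be argued in either direction; compound 4 is expected to remain near the weak end, with a number no higher from compound 2 to compound 4 (the limit leaves the size open) carrying the estimate. Compound 4 is expected at 10 uM in this assay, within the range 3 uM to 30 uM.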

Compound 4, minimum effective concentration: > 10 uM
Compound 4 was reported as a limit; the forecaster's own chance of this, stated with the estimate: 50%; the middle value lies on the limit itself.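

Compound 4, like compound 2, is reported only as a limit and not as a number, so the exchange of methoxy for methylsulfanyl gives no readable step between them: the limit of > 10 uM in this assay, at which 2 of the 4 values shown sit. The compounds shown leave open whether compound 2 and compound 4 differ at all.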